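The compounds below may be only part of what the source reports. "The series", "measured", "known", "first", "only" and "open" are said of these compounds alone.

Measured compounds:
Compound 1, `O=C1Nc2ccc(Br)cc2/C1=N/NC(=S)Nc1ccc(Cl)cc1`, 29000 nM.
Compound 2, `Cc1ccc(NC(=S)N/N=C2\C(=O)Nc3ccc(Br)cc32)cc1`, 4900 nM.
Compound 3, `O=C1/C(=N\NC(=S)Nc2ccc(Cl)cc2)c2cc(F)ccc2N1Cc1ccc(F)cc1`, 47000 nM.

All three values come from a functional assay on MOLT-4 cells (Homo sapiens), with a stated time of 72 h; on this read-out lower numbers stand for stronger inhibition and higher numbers for weaker inhibition. Compound 1 and compound 2 share a core and differ only in methyl in place of chloro on an aromatic carbon; that change gave a 5.9-fold lower number from compound 1 to compound 2 (0.77 log units; beyond the scatter). Compound 3 rests on a different core; the difference between the two cores is not broken down here. Compound 4, `Cc1ccc(NC(=S)N/N=C2\C(=O)N(Cc3ccc(F)cc3)c3ccc(F)cc32)cc1`, has not yet been measured in this assay; it differs from compound 3 by methyl in place of chloro on an aromatic carbon, the same change seen between compound 1 and compound 2. If the change acts on the core of compound 3 as it did on the core of compound 1, compound 4 is expected to show a 5.2-fold lower number from compound 3 to compound 4 (0.72 log units; beyond the scatter), because a 5.9-fold lower number from compound 1 to compound 2 (0.77 log units; beyond the scatter). On that basis compound 4 is estimated at 9000 nM, within 3000 nM to 30000 nM.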

Compound 4, half-maximal inhibitory concentration: 1500 nM
Estimate against measurement, compound 4: 6.0-fold (0.78 log units) above, and the stated range ends above it.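

In this assay, methyl in place of chloro on an aromatic carbon again gave a lower number on the second core, a 31-fold lower number from compound 3 to compound 4 (1.50 log units; beyond the scatter), so the direction of the step carried over from the core of compound 1 to the core of compound 3. Its size did not carry over: the same change on two cores in this assay, a 5.9-fold lower number (0.77 log units; beyond the scatter) from compound 1 to compound 2 and a 31-fold lower number (1.50 log units; beyond the scatter) from compound 3 to compound 4, 5.3-fold (0.72 log units) apart, beyond the scatter of two such steps. These two pairs show that the size of this step differs with the core, but they do not show which difference between the two cores goes with the larger step.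

From the compounds shown here alone, only chloro and methyl appear at this place, para to a large group, so the effect of a methoxy group, an amine or a carboxylic acid there remains open. Going by these compounds, whether either step size would recur on a third core is also open.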